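The compounds below may be only part of what the source reports. "The series", "measured", "known", "first", "only" and "open" are said of these compounds alone.

In a functional assay on HepG2 cells (Homo sapiens) for antiproliferative activity, read by sulforhodamine B assay, with a stated time of 48 h (a lower number here means a stronger inhibitor, a higher number a weaker inhibitor), compound 1 `COc1cccc(/C=C/C(=O)/C=C(O)/C=C/c2cccc(OC)c2OC)c1OC` gives 12900 nM. Compound 2 `COc1ccc(C=C(C(=O)/C=C/c2cccc(OC)c2OC)C(=O)/C=C/c2cccc(OC)c2OC)cc1O` gives 270 nM, and compound 3 `COc1ccc(OC)c(/C=C/C(=O)C(=Cc2ccc(O)c(OC)c2)C(=O)/C=C/c2cc(OC)ccc2OC)c1` gives 340 nM. Compound 3 therefore sits with compound 2, the two lying within the scatter of each other, while its number is lower than that of compound 1 by a margin well beyond the scatter.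

Compound 4 `COc1ccc(OC)c(/C=C/C(=O)C(=Cc2ccc(O)c(F)c2)C(=O)/C=C/c2cc(OC)ccc2OC)c1` keeps the frame of compound 3 but carries fluoro in place of methoxy on an aromatic carbon, ortho to a hydroxy group, turning 4-hydroxy-3-methoxyphenyl into 3-fluoro-4-hydroxyphenyl: fluoro in place of methoxy on an aromatic carbon. Within the data shown here, no measured pair here isolates this exchange. The nearest guide is that compound 2 at 270 nM and compound 3 at 340 nM stay close despite their different substitution. In this assay, no step beyond the scatter is therefore expected, and the estimated change is a 1.2-fold higher number from compound 3 to compound 4 (0.07 log units; within the scatter). For compound 4 the expected value is 400 nM, with an estimated range from 150 nM to 1000 nM.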

Compound 4, half-maximal inhibitory concentration: 220 nM
The estimate for compound 4 lay 1.8-fold (0.26 log units) above the measured number; the measured number falls inside the stated range.
By their numbers in this assay, from the lowest: compounds 4, 2 and 3 (each within the scatter of the next); then compound 1.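

Among these compounds, the position ortho to a hydroxy group, on the ring that carries 4-hydroxy-3-methoxyphenyl in compound 3, now has a direct reading for the first time. In this assay, turning this group into 3-fluoro-4-hydroxyphenyl gives a 1.5-fold lower number from compound 3 to compound 4 (0.19 log units; within the scatter), so within this frame, antiproliferative activity at this level does not depend on methoxy at this position, and the smaller fluoro serves equally well. Nothing available explains this outcome.

The compounds shown leave open how chloro, ethoxy or an amine would fare at this position, and whether a group much larger than methoxy would be accepted there as well. They also leave open whether fluoro could stand in for methoxy on the two outer dimethoxyphenyl rings, or in a compound lacking the hydroxy group.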